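A few compounds are considered here, and "the series" means these few. Any claim that something is new, unique, unknown or untested is made for them only; others in the source may bear on it.

Measured compounds:
- compound 1 `CN(C)C(=O)/C=C/CNCCOc1ccc(Oc2c(-c3ccc(F)cc3)sc3cc(O)ccc23)cc1` — 11900 nM
- compound 2 `O=C(/C=C/CNCCOc1ccc(Oc2c(-c3ccc(F)cc3)sc3cc(O)ccc23)cc1)N1CCC1` — 6560 nM

In a functional assay on Ishikawa cells (Homo sapiens) for antiproliferative activity, read by CCK-8 assay, with a stated time of 48 h (a lower number here means a stronger inhibitor, a higher number a weaker inhibitor), compound 2 gives the lowest of the two numbers; its nearest neighbour is compound 1, and the step of a 1.8-fold lower number from compound 1 to compound 2 (0.26 log units; within the scatter) lies within the scatter, so the two cannot be ordered.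

Compound 3 `C=C(C)C(=O)N1CC(Oc2ccc(Oc3c(-c4ccc(F)cc4)sc4cc(O)ccc34)cc2)C1` differs from compound 2 at the side chain on the shared core: 1-((1-methylethenyl)carbonyl)azetidin-3-yl in place of 2-((3-((azetidin-1-yl)carbonyl)prop-2-en-1-yl)amino)ethyl on an oxygen on an aromatic ring

Among the compounds with values here, the only measured step, from compound 1 to compound 2, concerns the group on the carbonyl carbon alone and was within the scatter. Within the data shown here, no measured pair changes the chain between the aromatic oxygen and the carbonyl, nor removes the hydrogen-bond donor counted in the leaving group, so nothing on hand speaks directly to this change. The step from compound 2 to compound 3 is therefore expected to be a 1.3-fold lower number from compound 2 to compound 3 (0.12 log units; within the scatter), that is, no clear direction beyond the scatter, with a wide margin in both directions.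

Compound 3 is estimated at 5000 nM in this assay, with a range from 1200 nM to 20000 nM.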

Compound 3, half-maximal inhibitory concentration: 14200 nM
Compound 3: the middle estimate sits 2.8-fold (0.45 log units) below what was measured, within the range that was stated.
By their numbers in this assay, from the lowest: compounds 2, 1 and 3 (each within the scatter of the next, the first and the last beyond it).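

In this assay, 1-((1-methylethenyl)carbonyl)azetidin-3-yl in place of 2-((3-((azetidin-1-yl)carbonyl)prop-2-en-1-yl)amino)ethyl on the aromatic oxygen gives a 2.2-fold higher number from compound 2 to compound 3 (0.34 log units; beyond the scatter), a modest step and the first in this small set to lie beyond the scatter. The same entering group, set against the 2-((3-(dimethylcarbamoyl)prop-2-en-1-yl)amino)ethyl group, gives a 1.2-fold higher number from compound 1 to compound 3 (0.08 log units; within the scatter), which is within the scatter, so the change at this position separates compound 3 from only one of the two amino-chain compounds and does not show a consistent effect. Nothing measured on these compounds accounts for the modest step seen against compound 2.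

Open, from the compounds shown here alone, is which part of the exchange goes with that step, as the groups differ at once in the amino nitrogen, the attachment of the four-membered ring and the count of hydrogen-bond donors, 1 leaving and 0 entering. A plain 2-aminoethyl group on the same oxygen, or a piperidin-4-yl ring carrying the same 1-methylethenyl carbonyl, would help pull these features apart.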